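This account rests on a few compounds, and the source may have more. Where it says the series, first, only, none or still open, it means among the compounds named here.

Measured so far in an ADME assay on U2OS cells (Homo sapiens) for cytotoxicity; on this read-out higher numbers stand for lower toxicity in this test and lower numbers for higher toxicity in this test:
compound 1 `CCCCNc1ccc(C(=O)N/N=C/c2ccc([N+](=O)[O-])o2)cc1`, 12000 nM;
compound 2 `CCCCCCc1ccc(C(=O)N/N=C/c2ccc([N+](=O)[O-])o2)cc1`, only a limit of the assay, > 200000 nM;
compound 3 `CCCCCC(=O)N/N=C/c1ccc([N+](=O)[O-])o1`, 19300 nM.

Compound 1 and compound 3 give numbers within the usual scatter of each other, and compound 2 reaches only a limit. Compound 4 `CCCCOc1ccc(C(=O)N/N=C/c2ccc([N+](=O)[O-])o2)cc1` differs from compound 1 by butoxy in place of butylamino on an aromatic carbon. Within the data shown here, the one measured step at this same place, an at least 16-fold higher number from compound 1 to compound 2 (1.22 log units; beyond the scatter), was large and upward, but butylamino there gave way to hexyl, a bigger change than to butoxy. An upward step is therefore expected for compound 4 in this assay, smaller than that one, near the edge of the scatter, estimated as a 2.1-fold higher number from compound 1 to compound 4 (0.32 log units; beyond the scatter). Compound 4 is expected to give about 25000 nM, in the range 7000 nM to 90000 nM.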

Compound 4, half-maximal cytotoxic concentration: 46600 nM
Compound 4: middle estimate off by 1.9-fold (0.27 log units), on the low side; measured number inside the range.
By their numbers in this assay, from the lowest: compounds 1 and 3 (each within the scatter of the next); then compound 4. At a limit, above all of these: compound 2.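

Butoxy and butylamino both have 5 heavy atoms, so this change leaves the size of the group alike but removes its hydrogen-bond donor and puts oxygen for nitrogen. Even so, in this assay it gives a 3.9-fold higher number from compound 1 to compound 4 (0.59 log units; beyond the scatter). Hexyl stays apart from butoxy, with an at least 4.2-fold lower number from compound 2 to compound 4 (0.63 log units; beyond the scatter), and compound 2 is read only at a limit: the limit of > 200000 nM in this assay, at which 1 of the 4 values shown sits.

The compounds shown cannot separate the loss of the donor from the oxygen itself. As far as these compounds go, how a carboxylic acid or a longer alkoxy chain would read at this place stays open.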